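The source may report more compounds than this note shows. Statements on the series, on what has been measured and on what is new or still open speak of the compounds shown alone.

Working notes on the series. Compound 1 `CC1(C)OC[C@H](Cn2cc(-c3ccc([N+](=O)[O-])cc3)nn2)O1` and compound 2 `O=[N+]([O-])c1ccc(-c2cn(Cc3ccccc3)nn2)cc1` share one core; compound 3 `COc1ccc(-c2cn(C[C@H]3COC(C)(C)O3)nn2)c(OC)c1OC` and compound 4 `COc1ccc(-c2cn(Cc3ccccc3)nn2)c(OC)c1OC` share another, and the difference between the two cores is not broken down here. In a functional assay on B16 cells (Mus musculus) for cytotoxicity, read by MTT assay, with a stated time of 48 h (a higher number here means a weaker inhibitor, a lower number a stronger inhibitor), compound 1 reaches only a limit, > 100000 nM. Compound 2 gives 5120 nM in this assay. The change that separates them is phenyl in place of 2,2-dimethyl-1,3-dioxolan-4-yl on a saturated chain carbon bound to an aromatic nitrogen, and it produced an at least 19-fold lower number from compound 1 to compound 2 (1.29 log units; beyond the scatter). Compound 3 also reaches only a limit in this assay, > 100000 nM. Two of the three values sit at the limit of > 100000 nM in this assay, at which 2 of the 3 values shown sit. Compound 4 carries the same change, (phenyl in place of 2,2-dimethyl-1,3-dioxolan-4-yl on a saturated chain carbon bound to an aromatic nitrogen), so a step of the same direction is anticipated, though its true size is hidden by the limit of compound 3. Compound 4 is expected to give 25000 nM in this assay, with the expected range running from 4000 nM to 100000 nM. That corresponds to an expected step of an at least 4.0-fold lower number from compound 3 to compound 4 (0.60 log units; beyond the scatter).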

Compound 4, half-maximal inhibitory concentration: 27500 nM
Compound 4: the middle estimate sits 1.1-fold (0.04 log units) below what was measured; measured number inside the range.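

The change of 2,2-dimethyl-1,3-dioxolan-4-yl to phenyl on a saturated chain carbon bound to an aromatic nitrogen acts in the same direction on the second core in this assay, with an at least 3.6-fold lower number from compound 3 to compound 4 (0.56 log units; beyond the scatter). Direction therefore carries over between the two cores shown, while size cannot be compared: the same change on two cores in this assay, an at least 19-fold lower number (1.29 log units; beyond the scatter) from compound 1 to compound 2 and an at least 3.6-fold lower number (0.56 log units; beyond the scatter) from compound 3 to compound 4; the limit leaves it open whether they differ. Both steps start from a limit, so whether the change is worth the same on each core stays unresolved: the limit of > 100000 nM in this assay, at which 2 of the 4 values shown sit.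

The compounds shown leave open how a cyclohexyl group, an amine or a longer chain would behave in that place. They also leave open whether the step would hold on any further core.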